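This account rests on a few compounds, and the source may have more. Where it says the series, first, only, none or still open, it means among the compounds named here.

- compound 1 `Cc1ccc(C2=NN(c3ccc(S(C)(=O)=O)cc3)C(=O)CC2)cc1`: 410 nM
- compound 2 `Cc1cc(O)ccc1C1=NN(c2ccc(S(C)(=O)=O)cc2)C(=O)CC1`: 3780 nM

In a functional assay on HCT-116 cells (Homo sapiens) for inhibition, read by sulforhodamine B assay, with a stated time of 48 h (on this read-out lower numbers stand for stronger inhibition of growth and higher numbers for weaker inhibition of growth), compound 2 has the higher of the two numbers, 3780 nM, which makes it the weaker growth inhibitor of the pair. Compound 3 `CCc1ccc(C2=NN(c3ccc(S(C)(=O)=O)cc3)C(=O)CC2)cc1` has not yet been measured. Its structure departs from that of compound 2 as follows: 4-ethylphenyl in place of 4-hydroxy-2-methylphenyl on a carbon with a double bond to nitrogen. In words, 4-ethylphenyl stands in place of 4-hydroxy-2-methylphenyl on a carbon with a double bond to nitrogen.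

Within the data shown here, only one measured step bears on this change: a 9.2-fold higher number from compound 1 to compound 2 (0.96 log units; beyond the scatter). That modest step, beyond the scatter, came with 4-hydroxy-2-methylphenyl replacing 4-methylphenyl. Compound 3 carries 4-ethylphenyl, so it resembles compound 1 in having no hydroxy group, but with ethyl where compound 1 has methyl. Among the measured compounds shown here, no measured compound shows what that difference does, so the range must stay wide. A step of similar size towards a lower number is therefore expected, and the expected step is a 7.6-fold lower number from compound 2 to compound 3 (0.88 log units; beyond the scatter). For compound 3, the estimated value is 500 nM, with an expected range from 170 nM to 1500 nM.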

Compound 3, concentration for 50% growth inhibition: 730 nM
For compound 3 the middle estimate is 1.5-fold (0.16 log units) below the measured one, and the stated range covers the measured number.
By their numbers in this assay, from the lowest: compounds 1 and 3 (each within the scatter of the next); then compound 2.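

In this assay the change to 4-ethylphenyl gives a 5.2-fold lower number from compound 2 to compound 3 (0.71 log units; beyond the scatter), a modest step beyond the scatter, so a second ring without a hydroxy group also gives a clearly lower number than compound 2. The comparison that is new here is a 1.8-fold higher number from compound 1 to compound 3 (0.25 log units; within the scatter), which lies within the scatter: on the carbon with a double bond to nitrogen, ethyl in place of the methyl of 4-methylphenyl makes no difference that this assay can separate from the variation between repeated measurements. Among these compounds, compound 2 is thus the only compound of the three that carries a hydroxy group, and it stands apart from both compound 1 and compound 3, although three compounds are too few to call this a rule.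

No measurement given here explains why these numbers differ. Going by these compounds, it remains open whether the hydroxy group or the methyl of 4-hydroxy-2-methylphenyl accounts for the number of compound 2, and whether a longer chain such as propyl, or an amine on the ring, would keep growth inhibition at the level of compound 1 and compound 3.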